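An amide swap at the far end of compound 2

The source may hold more compounds than are shown below. What is called first, only, known or untested is meant among the compounds shown, and "the series" means these compounds.

compound 1, `COCOc1ccc(/C=C/C(=O)N2CCN(Cc3ccc(Cl)c(Cl)c3)CC2)cc1OCOC`: 139000 nM
compound 2, `O=C(COC(=O)/C=C/c1ccc(O)c(O)c1)NN1CCOCC1`: > 200000 nM
compound 3, `COc1ccc(NC(=O)COC(=O)/C=C/c2cc(OC)c(OCc3ccccc3)c(OC)c2)cc1`: > 200000 nM

All three were tested in a functional assay on LS174T cells (Homo sapiens) for cytotoxicity, read by MTT assay, with a stated time of 72 h; a lower number here means a stronger inhibitor, a higher number a weaker inhibitor. Compound 1 gives a measured number. For compound 2 the value is only a limit of the assay, not a number. For compound 3, too, only a limit is reported. Compound 2 therefore stands at the limit of > 200000 nM in this assay, at which 2 of the 3 values shown sit, sharing that position with compound 3.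

Compound 4, `O=C(COC(=O)/C=C/c1ccc(O)c(O)c1)Nc1ccc(Cl)cc1`, differs from compound 2 by 4-chlorophenyl in place of morpholin-4-yl on an amide-type nitrogen. Among the measured compounds shown here, no step between measured compounds is known, so no size can be read from the data. Compound 4 is expected to stay near the limit, and an at least 1.1-fold lower number from compound 2 to compound 4 (0.04 log units; that floor lies within the scatter) is expected to be no step beyond the scatter. Compound 4 is estimated at 180000 nM, within 80000 nM to 400000 nM.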

Compound 4, half-maximal inhibitory concentration: 108000 nM
For compound 4 the middle estimate is 1.7-fold (0.22 log units) above the measured one; the range from low to high includes it.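

In this assay, 4-chlorophenyl in place of morpholin-4-yl on the amide-type nitrogen gives an at least 1.8-fold lower number from compound 2 to compound 4 (0.26 log units; that floor lies within the scatter). This shows that a change at this position can bring a measured number in this series, yet the floor of that step lies within the usual scatter and proves no real difference on its own. Compound 2 has only a limit of the assay, and the full size of the step therefore stays unknown: the limit of > 200000 nM in this assay, at which 2 of the 4 values shown sit.

From the compounds shown here alone, whether the ring or its chlorine matters more remains open. A plain phenyl on this nitrogen would help separate the two.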